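This account rests on a few compounds, and the source may have more. Where it says the series, first, only, none or still open, it means among the compounds named here.

Going by the values given here, in a functional assay on HeLa cells (Homo sapiens) for cytotoxicity, read by MTT assay (on this read-out higher numbers stand for weaker inhibition and lower numbers for stronger inhibition), compound 2 `C/C=C(\C)C(=O)O[C@@H]1[C@@H]2OC[C@]3(C)[C@H](OC(C)=O)C[C@H](O)[C@@](C)([C@@H]23)[C@H]2C[C@H](O)O[C@H]3C[C@@H](C4=CCOC4=O)C(C)=C3[C@]12C` gives 32000 nM, the only actual number so far. Compound 1 `C/C=C(\C)C(=O)O[C@@H]1[C@@H]2OC[C@]3(C)[C@H](OC(C)=O)C[C@H](O)[C@@](C)([C@@H]23)[C@H]2C[C@H](OC)O[C@H]3C[C@@H](C4=CCOC4=O)C(C)=C3[C@]12C` reads > 100000 nM, which is a limit of the assay and not a number. Compound 3 `C/C=C(\C)C(=O)O[C@@H]1[C@@H]2OC[C@]3(C)[C@H](OC(C)=O)C[C@H](O)[C@@](C)([C@@H]23)[C@H]2C[C@H](OCC)O[C@H]3C[C@@H](C4=CCOC4=O)C(C)=C3[C@]12C` differs from compound 2 by ethyl in place of hydrogen on an oxygen on a saturated carbon: ethyl in place of hydrogen, turning hydroxy into ethoxy, while compound 1 has methyl on that oxygen. Among the compounds with values here, the one measured step bearing on this is an at least 3.1-fold lower number from compound 1 to compound 2 (0.49 log units; beyond the scatter), so capping the hydroxy with ethyl is expected to reverse it, toward weaker inhibition. The expected change is a 2.8-fold higher number from compound 2 to compound 3 (0.45 log units; beyond the scatter). The estimated value for compound 3 is 90000 nM, with an expected range of 35000 nM to 250000 nM.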

Compound 3, half-maximal inhibitory concentration: > 100000 nM
Compound 3: no number, only a limit; the forecaster's own chance of this, stated with the estimate: 50%; middle value at least 1.1-fold (0.04 log units) away from the limit.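

Ethyl on this oxygen gives an at least 3.1-fold higher number from compound 2 to compound 3 (0.49 log units; beyond the scatter) in this assay and so shows that the loss seen with methyl in compound 1 is not confined to that one group. Of the three compounds, only compound 2, with the free hydroxy, gives a number. The step between compound 1 and compound 3 cannot be read because both stop at a limit of the assay: the limit of > 100000 nM in this assay, at which 2 of the 3 values shown sit.

On these data alone, whether a longer chain such as propyl on this oxygen would also stay at that limit remains open. So does whether an amine in place of the hydroxy would keep or improve on the number of compound 2.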